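The source may report more compounds than this note shows. Statements on the series, on what has been measured and on what is new or still open speak of the compounds shown alone.

Of the compounds shown here, two have so far been measured in an assay on HEK293 cells for displacement of a labelled ligand from Orexin receptor type 2 (Homo sapiens), read by scintillation counting, with a stated time of 90 min; on this read-out higher numbers stand for weaker inhibition and lower numbers for stronger inhibition. Compound 1 `COc1ccc(N2C(=O)N(Cc3ccc(F)cc3Cl)c3ccccc3S2(=O)=O)cc1OC` gives 25.1 nM, and compound 2 `COc1cc(N2C(=O)N(Cc3c(F)cc(F)cc3F)c3ccccc3S2(=O)=O)ccn1` gives 63.1 nM. Compound 1 thus has the lower of the two numbers, and its gap to compound 2 lies beyond the usual scatter of this assay. Compound 3 `COc1ccc(N2C(=O)N(Cc3ccccc3)c3ccccc3S2(=O)=O)cc1OC` has not yet been measured. It differs from compound 1 in one place: phenyl in place of 2-chloro-4-fluorophenyl on a saturated chain carbon bound to an amide-type nitrogen in a ring. Among the measured compounds there is no pair that isolates this change, so the expectation rests on compound 1 alone and on the fact that only the two halogens are lost. Such a loss is expected to weaken inhibition moderately, so the step from compound 1 to compound 3 is expected to raise the number by about a 4.0-fold higher number from compound 1 to compound 3 (0.60 log units; beyond the scatter). For compound 3 the estimated value in this assay is 100 nM, with a range from 30 nM to 400 nM.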

Compound 3, inhibition constant: 79.4 nM
Compound 3: middle estimate off by 1.3-fold (0.10 log units), on the high side, and the stated range covers the measured number.
By their numbers in this assay, from the lowest: compound 1; then compounds 2 and 3 (each within the scatter of the next).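

In this assay, putting phenyl in place of 2-chloro-4-fluorophenyl on the shared core gives a 3.2-fold higher number from compound 1 to compound 3 (0.50 log units; beyond the scatter). For the compounds shown here, this is the first pair that differs in one place, and it shows that this position responds to the change: losing both halogens together weakens inhibition by more than the usual scatter, but inhibition is still measurable without them. No supporting data bear on what lies behind this shift.

As far as these compounds go, both halogens leave in the same step, so the separate shares of the chlorine and the fluorine remain open, and a ring carrying only one of them would separate the two. Also open, from the compounds shown here alone, is how this position would respond to a different kind of group, such as an amine on the ring or a longer chain in place of the benzyl.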